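Amino-for-fluoromethoxy swap on the pendant aryl of compound 1

The source may report more compounds than this note shows. Statements on the series, on what has been measured and on what is new or still open speak of the compounds shown alone.

Among the measured compounds shown here, compound 1 `COc1ccc(-c2ccc3ncn(-c4cc(OC)c(OC)c(OC)c4)c3c2)cc1F` gives 520 nM in a functional assay on MCF7 cells (Homo sapiens) for antiproliferative activity, read by MTT assay, with a stated time of 72 h (a higher number here means a weaker inhibitor, a lower number a stronger inhibitor), the lowest of the two numbers so far. For the measured compounds named here, compound 2 `COc1cc(-n2cnc3ccc(-c4cccc(F)c4)cc32)cc(OC)c1OC` gives 2350 nM in this assay, and the only measured step, a 4.5-fold higher number from compound 1 to compound 2 (0.66 log units; beyond the scatter), shows that losing the methoxy costs potency. Compound 3 `COc1cc(-n2cnc3ccc(-c4cccc(N)c4)cc32)cc(OC)c1OC` differs from compound 1 by 3-aminophenyl in place of 3-fluoro-4-methoxyphenyl on an aromatic carbon. Going by the values given here, no step on file bears directly on the amino group; only the loss of the methoxy is covered, so a weakening of a size similar to that step is expected, giving a 2.9-fold higher number from compound 1 to compound 3 (0.46 log units; beyond the scatter). For compound 3 the estimate in this assay is 1500 nM, with a range from 500 nM to 5000 nM.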

Compound 3, half-maximal inhibitory concentration: 180 nM
Beside the measured number, compound 3's estimate is 8.3-fold (0.92 log units) above it, outside the stated range (below it).
By their numbers in this assay, from the lowest: compound 3; then compound 1; then compound 2.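

Amino in place of fluoro on the pendant ring gives a 13-fold lower number from compound 2 to compound 3 (1.12 log units; beyond the scatter), so the methoxy of compound 1 is not required for potency at this position once the amino group is present. The 3-aminophenyl ring also outperforms the 3-fluoro-4-methoxyphenyl ring, with a 2.9-fold lower number from compound 1 to compound 3 (0.46 log units; beyond the scatter). No evidence on hand explains this gain.

As far as these compounds go, whether a methylamino, dimethylamino or acetamido group at the same place keeps the gain remains open. So does the effect of adding a methoxy group to the aminophenyl ring of compound 3.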